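Swapping the Aryl Group on the Ring Nitrogen

The source may hold more compounds than are shown below. What is called first, only, known or untested is meant among the compounds shown, and "the series" means these compounds.

Measured so far:
compound 1, `C=CC(=O)Nc1cc(Nc2ncc3ncn(-c4ccc(C)cc4)c3n2)c(OC)cc1N(C)CCN(C)C` — 9230 nM
compound 2, `C=CC(=O)Nc1cc(Nc2ncc3ncn(-c4ccccc4F)c3n2)c(OC)cc1N(C)CCN(C)C` — 9750 nM

Of the compounds shown here, two have been measured in an ADME assay on HT-29 cells (Homo sapiens) for cytotoxicity, read by MTT assay, with a stated time of 72 h; a higher number here means a weaker inhibitor, a lower number a stronger inhibitor. Compound 1 gives 9230 nM. Compound 2 gives 9750 nM. The two numbers sit within the scatter of each other, so compound 1 cannot be called stronger or weaker than compound 2 on these data.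

Compound 3 `C=CC(=O)Nc1cc(Nc2ncc3ncn(-c4ccc(F)c(Br)c4)c3n2)c(OC)cc1N(C)CCN(C)C` is not yet measured. It differs from compound 1 in one place: 3-bromo-4-fluorophenyl in place of 4-methylphenyl on an aromatic nitrogen

For the measured compounds named here, only one measured step bears on this change. It is a 1.1-fold higher number from compound 1 to compound 2 (0.02 log units; within the scatter), which also exchanges the group on the same aromatic nitrogen and leaves the number essentially unchanged. On that basis, compound 3 is expected to show no step beyond the scatter, the expected step being a 1.0-fold higher number from compound 1 to compound 3 (0.01 log units; within the scatter). For compound 3 the estimate is 9500 nM, with a range from 4500 nM to 20000 nM.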

Compound 3, half-maximal inhibitory concentration: 3640 nM
Beside the measured number, compound 3's estimate is 2.6-fold (0.42 log units) above it; measured number below the stated range.
By their numbers in this assay, from the lowest: compound 3; then compounds 1 and 2 (each within the scatter of the next).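

The aryl group on this aromatic nitrogen can change the number: in this assay, 3-bromo-4-fluorophenyl in place of 4-methylphenyl gives a 2.5-fold lower number from compound 1 to compound 3 (0.40 log units; beyond the scatter), and in place of 2-fluorophenyl it gives a 2.7-fold lower number from compound 2 to compound 3 (0.43 log units; beyond the scatter). Both steps are modest, but they lie beyond the scatter, unlike the earlier exchange of 4-methylphenyl for 2-fluorophenyl, so the position is not indifferent to every aryl group placed on it. Nothing measured here accounts for the lower number of compound 3.

As far as these compounds go, it remains open whether 3-bromophenyl or 4-fluorophenyl alone would give a similar step, or whether the lower number needs both halogens on the ring. Also open, from the compounds shown here alone, is how the number would respond to an aryl group carrying an amine or a carboxylic acid at this position.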